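A few compounds are considered here, and "the series" means these few. Any claim that something is new, unique, unknown or untested is made for them only; others in the source may bear on it.

Compound 1 `CCOc1ccc(C(=O)/C=C/c2ccc(N(C)C)cc2)cc1` — 210 nM
Compound 2 `COc1ccc(/C=C/C(=O)c2ccc(ON=C3CCCCC3)cc2)cc1` — < 300 nM
Compound 3 `COc1ccc(C(=O)/C=C/c2ccc(O/N=C(\C)c3ccccc3)cc2)cc1` — > 200 nM

Among the measured compounds shown here, in an assay on isolated protein for inhibition of Amine oxidase [flavin-containing] B (Homo sapiens) (on this read-out lower numbers stand for stronger inhibition and higher numbers for weaker inhibition), compound 1 gives the only fixed number of the three, 210 nM. For compound 2 the assay reports only a limit, < 300 nM. For compound 3 the assay likewise reports only a limit, > 200 nM. Compound 1 is therefore the one anchor from which a step can be followed. Compound 4 `CCOc1ccc(C(=O)/C=C/c2ccc(CC)cc2)cc1` has not been measured; it differs from compound 1 by ethyl in place of dimethylamino on an aromatic carbon. No measured pair among these compounds shows the effect of such a change, so the direction rests on expectation alone: a step in this assay toward weaker inhibition, modest but beyond the usual scatter, is expected from compound 1 to compound 4, namely a 2.6-fold higher number from compound 1 to compound 4 (0.42 log units; beyond the scatter). Compound 4 is accordingly estimated at 550 nM, with a range from 150 nM to 2000 nM.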

Compound 4, half-maximal inhibitory concentration: 210 nM
Compound 4: the middle estimate sits 2.6-fold (0.42 log units) above what was measured, within the range that was stated.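

In this assay, among the compounds shown here, setting ethyl in place of dimethylamino on this aromatic carbon, para to a large group, gives no change at the digits printed from compound 1 to compound 4 (within the scatter) and so provides the first readable step. In this pair, the hydrogen-bond acceptor counted for dimethylamino leaves and none enters, with inhibition holding level. Nothing shown gives a reason for this outcome. Going by these compounds, whether a carboxylic acid or a longer chain at this carbon would also hold the number remains open. Steps involving compound 2 and compound 3 cannot be read, since each has only a limit.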